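This account rests on a few compounds, and the source may have more. Where it says the series, first, only, none or still open, it means among the compounds named here.

For the measured compounds named here, the three compounds measured so far share one core and differ only in the group carried on the ring nitrogen. Compound 1 `CCC(=O)N(C)c1ccc2[nH]c(-c3n[nH]c4ccccc34)cc2n1` gives 10800 nM in a functional assay on HCT-116 cells (Homo sapiens) for antiproliferative activity, read by MTT assay, with a stated time of 72 h; a higher number here means a weaker inhibitor, a lower number a stronger inhibitor. Compound 2 `COc1ccc(C(=O)N(C)c2ccc3[nH]c(-c4n[nH]c5ccccc45)cc3n2)cc1` gives 29500 nM in this assay, and compound 3 `COc1cccc(C(=O)N(C)c2ccc3[nH]c(-c4n[nH]c5ccccc45)cc3n2)c1` gives 14200 nM. Compound 3 therefore holds the second highest of the three numbers: the step of a 1.3-fold higher number from compound 1 to compound 3 (0.12 log units; within the scatter) stays within the scatter, while the step of a 2.1-fold lower number from compound 2 to compound 3 (0.32 log units; beyond the scatter) is a modest one. The third step, a 2.7-fold higher number from compound 1 to compound 2 (0.44 log units; beyond the scatter), is also modest.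

Compound 4 `CN(c1ccc2[nH]c(-c3n[nH]c4ccccc34)cc2n1)S(=O)(=O)c1ccccc1` differs from compound 3 in one place: phenylsulfonyl in place of (3-methoxyphenyl)carbonyl on a nitrogen on an aromatic ring. Going by the values given here, no measured pair exchanges the carbonyl itself for a sulfonyl, so the only steps that bear on this change are the three exchanges of the group on the carbonyl carbon, all of which moved the number by a modest amount or not at all beyond the scatter. On that basis compound 4 is expected to give about 14000 nM in this assay, within a range of 5000 nM to 40000 nM. The expected step, a 1.0-fold lower number from compound 3 to compound 4 (0.01 log units; within the scatter), would be small, with no clear direction beyond the scatter.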

Compound 4, half-maximal inhibitory concentration: 6740 nM
Beside the measured number, compound 4's estimate is 2.1-fold (0.32 log units) above it; low and high end bracket the measured number.
By their numbers in this assay, from the lowest: compounds 4, 1 and 3 (each within the scatter of the next, the first and the last beyond it); then compound 2.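

For the compounds shown here, at the nitrogen on an aromatic ring, the change to phenylsulfonyl is the first to replace the carbonyl link itself, and in this assay it does not raise the number: the result is a 2.1-fold lower number from compound 3 to compound 4 (0.32 log units; beyond the scatter) and a 4.4-fold lower number from compound 2 to compound 4 (0.64 log units; beyond the scatter), the latter being the largest step so far. Against the small propanoyl group, the change gives a 1.6-fold lower number from compound 1 to compound 4 (0.20 log units; within the scatter), so an aromatic ring carried on a sulfonyl sits level with the ethyl-bearing carbonyl, whereas the (4-methoxyphenyl)carbonyl group of compound 2 does not. Nothing available here accounts for these steps.

The compounds shown leave open how much of the step from compound 3 belongs to the sulfonyl and how much to the loss of the methoxy group, since both change together; a (3-methoxyphenyl)sulfonyl group or a plain benzoyl group would separate the two. They also leave open how an ethylsulfonyl group, which would pair directly with the propanoyl group of compound 1, or an amine on the phenyl ring would read at this nitrogen.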